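A few compounds are considered here, and "the series" means these few. Any claim that something is new, unique, unknown or untested is made for them only; others in the source may bear on it.

Three measured compounds share one core and differ only in the aryl group carried by the urea. Compound 1 `COc1cc(Cl)cc(-c2nn(-c3cccc(NC(=O)Nc4ccc(Cl)c(C(F)(F)F)c4)c3)cc2-c2ccncc2)c1` gives 630 nM in a functional assay on HCT-116 cells (Homo sapiens) for inhibition, read by sulforhodamine B assay, with a stated time of 48 h; a lower number here means a stronger inhibitor, a higher number a weaker inhibitor. Compound 2 `COc1cc(Cl)cc(-c2nn(-c3cccc(NC(=O)Nc4ccc(Cl)c(Cl)c4)c3)cc2-c2ccncc2)c1` gives 2020 nM in this assay, and compound 3 `COc1cc(Cl)cc(-c2nn(-c3cccc(NC(=O)Nc4cccc(C(F)(F)F)c4)c3)cc2-c2ccncc2)c1` gives 750 nM in this assay. Among these three numbers compound 3 stands second highest: its nearest neighbour is compound 1, with a 1.2-fold higher number from compound 1 to compound 3 (0.08 log units; within the scatter), a gap within the scatter, while compound 2 lies further off, with a 2.7-fold lower number from compound 2 to compound 3 (0.43 log units; beyond the scatter). For the measured compounds named here, the third step, a 3.2-fold higher number from compound 1 to compound 2 (0.51 log units; beyond the scatter), also concerns only that aryl group.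

Compound 4 `COc1cc(Cl)cc(-c2nn(-c3cccc(NC(=O)c4cccc(C(F)(F)F)c4)c3)cc2-c2ccncc2)c1` changes something else: 3-(trifluoromethyl)phenyl in place of (3-(trifluoromethyl)phenyl)amino on a carbonyl carbon. None of the three measured steps touches the carbonyl or the amide-type nitrogen, so none of them bears directly on this step, and the data give no direct guide to its size or direction. The largest measured step anywhere in the set, a 3.2-fold higher number from compound 1 to compound 2 (0.51 log units; beyond the scatter), was modest. On that basis compound 4 is expected to sit somewhat higher than compound 3 in this assay, with wide uncertainty. The expected step is a 2.0-fold higher number from compound 3 to compound 4 (0.30 log units; within the scatter). Compound 4 is estimated at 1500 nM, with a range from 400 nM to 6000 nM.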

Compound 4, half-maximal inhibitory concentration: 3170 nM
Beside the measured number, compound 4's estimate is 2.1-fold (0.32 log units) below it; measured number inside the range.
By their numbers in this assay, from the lowest: compounds 1 and 3 (each within the scatter of the next); then compounds 2 and 4 (each within the scatter of the next).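

In this assay, the carbonyl's nitrogen neighbour, which no earlier step touched, proves to matter: with the 3-(trifluoromethyl)phenyl group kept, replacing (3-(trifluoromethyl)phenyl)amino on the carbonyl carbon gives a 4.2-fold higher number from compound 3 to compound 4 (0.63 log units; beyond the scatter), so the urea link does not behave as a neutral part of these compounds. Measured against the other two ureas, where the group that leaves also carries different aryl substituents, the change reads a 5.0-fold higher number from compound 1 to compound 4 (0.70 log units; beyond the scatter) and a 1.6-fold higher number from compound 2 to compound 4 (0.20 log units; within the scatter), and the latter gives no order between those two compounds. No measured evidence here accounts for the effect of this change.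

The compounds shown leave open whether the loss follows from removing the amide hydrogen or the nitrogen atom itself, a distinction that a methyl group on that nitrogen, or an oxygen atom or a methylene group in its place, could help to settle. They also leave open whether a longer chain between the carbonyl and the aryl ring would recover the numbers seen with the ureas.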